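Lengthening the fluorinated chain from compound 3 to compound 4

The source may hold more compounds than are shown below. What is called first, only, known or untested is meant among the compounds shown, and "the series" means these compounds.

Values measured in a physicochemical assay for solubility, in simulated intestinal fluid, measured as thermodynamic solubility, at pH 6.5 (on this read-out higher numbers stand for higher solubility and lower numbers for lower solubility), for three compounds:
- compound 1 `CCCOc1nc(OCC(C)(C)O)c(-c2ccc(S(C)(=O)=O)cc2)cc1CO` gives 25000 nM
- compound 2 `CCCCOc1nc(OCC(C)(C)O)c(-c2ccc(S(C)(=O)=O)cc2)cc1CO` gives 66500 nM
- compound 3 `CC(C)(O)COc1nc(OCCC(F)(F)F)c(CO)cc1-c1ccc(S(C)(=O)=O)cc1` gives 44400 nM

Compound 3 stands at 44400 nM in this small set and lies within the scatter of both others. The data show a 1.8-fold higher number from compound 1 to compound 3 (0.25 log units; within the scatter) and also a 1.5-fold lower number from compound 2 to compound 3 (0.18 log units; within the scatter) on the same read-out. Only the other pair is separated beyond the scatter, with a 2.7-fold higher number from compound 1 to compound 2 (0.42 log units; beyond the scatter) between them.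

Compound 4 `CC(C)(O)COc1nc(OCCCC(F)(F)F)c(CO)cc1-c1ccc(S(C)(=O)=O)cc1` has not yet been measured and carries a single change: 2,2,2-trifluoroethyl in place of trifluoromethyl on a saturated chain carbon, two bonds along the chain from an oxygen on an aromatic ring which takes the side chain from 3,3,3-trifluoropropoxy to 4,4,4-trifluorobutoxy. The closest measured change also lengthens a chain, and it gave a 2.7-fold higher number from compound 1 to compound 2 (0.42 log units; beyond the scatter) on a chain without fluorine. Going by the values given here, that is one modest step, and no measured pair lengthens a fluorinated chain, so the precedent carries limited weight. A small rise is therefore expected, quite possibly not beyond the scatter. The estimated change is a 1.4-fold higher number from compound 3 to compound 4 (0.13 log units; within the scatter) in the direction of that precedent but smaller. In this assay compound 4 is estimated at 60000 nM with an expected range of 25000 nM to 140000 nM.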

Compound 4, solubility: 111000 nM
The estimate for compound 4 lay 1.9-fold (0.27 log units) below the measured number; the measured number falls inside the stated range.
By their numbers in this assay, from the lowest: compounds 1, 3, 2 and 4 (each within the scatter of the next, the first and the last beyond it).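

In this assay, lengthening the fluorinated chain from 3,3,3-trifluoropropoxy to 4,4,4-trifluorobutoxy gives a 2.5-fold higher number from compound 3 to compound 4 (0.40 log units; beyond the scatter) and so shows a step beyond the scatter on a fluorinated chain, while the earlier precedent, a 2.7-fold higher number from compound 1 to compound 2 (0.42 log units; beyond the scatter) on a chain without fluorine, had shown one only there. Among these compounds, the added chain carbon therefore goes with a higher number both with and without the fluorines, and neither pair goes against this. Trifluoromethyl in place of methyl stays within the scatter at the longer chain, with a 1.7-fold higher number from compound 2 to compound 4 (0.22 log units; within the scatter) as printed, just as it did at the shorter chain with a 1.8-fold higher number from compound 1 to compound 3 (0.25 log units; within the scatter) as printed, whereas the two changes taken together give a 4.4-fold higher number from compound 1 to compound 4 (0.65 log units; beyond the scatter) and separate the two compounds clearly.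

Nothing shown here accounts for why the added chain carbon goes with these numbers.
The compounds shown also leave open whether a longer chain than 4,4,4-trifluorobutoxy would continue the rise in this assay or reverse it, and how a chain ending in an amine or a carboxylic acid would compare at this place.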